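The source may report more compounds than this note shows. Statements on the series, on what has been measured and on what is new or still open speak of the compounds shown alone.

Compound 1, `COC(=O)Cn1cc(CO[C@H]2CC(=O)[C@@H]3OC[C@H]2O3)nn1`, gives 21300 nM.
Compound 2, `O=C1C[C@H](OCc2cn(C(=O)c3ccccc3)nn2)[C@H]2CO[C@@H]1O2`, gives 25900 nM.
Compound 3, `O=C1C[C@H](OCc2cn(-c3ccc([N+](=O)[O-])cc3)nn2)[C@H]2CO[C@@H]1O2`, gives 24800 nM.

All three numbers come from a functional assay on MDA-MB-231 cells (Homo sapiens) for cytotoxicity, read by MTT assay, with a stated time of 48 h; on this read-out lower numbers stand for stronger inhibition and higher numbers for weaker inhibition. Compound 3 stands second highest of the three; its nearest neighbour is compound 2 with 25900 nM, and the furthest is compound 1 with 21300 nM, both gaps lying within the scatter. Compound 4, `O=C1C[C@H](OCc2cn(-c3ccccc3)nn2)[C@H]2CO[C@@H]1O2`, differs from compound 3 by hydrogen in place of nitro on an aromatic carbon, the site being an aromatic carbon of a six-membered aromatic ring of carbon only. Within the data shown here, the single measured step, a 1.2-fold higher number from compound 1 to compound 2 (0.08 log units; within the scatter), changes the substituent on the aromatic nitrogen rather than the ring that carries the nitro group, so no measured step touches this change directly; what the data show is that the three measured values sit within the scatter of one another. Compound 4 is therefore expected to move by a 1.0-fold lower number from compound 3 to compound 4 (0.01 log units; within the scatter) in this assay, nothing beyond the scatter. The estimate for compound 4 is 24000 nM, with a range from 10000 nM to 55000 nM.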

Compound 4, half-maximal inhibitory concentration: 25200 nM
The estimate for compound 4 lay 1.1-fold (0.02 log units) below the measured number; measured number inside the range.
By their numbers in this assay, from the lowest: compounds 1, 3, 4 and 2 (each within the scatter of the next).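

Hydrogen in place of nitro on an aromatic carbon is a step of a 1.0-fold higher number from compound 3 to compound 4 (0.01 log units; within the scatter) in this assay, so this position, para to a large group, shows no response beyond the scatter to losing the nitro group. On the aromatic nitrogen, phenyl in place of benzoyl gives a 1.0-fold lower number from compound 2 to compound 4 (0.01 log units; within the scatter), and phenyl in place of (methoxycarbonyl)methyl gives a 1.2-fold higher number from compound 1 to compound 4 (0.07 log units; within the scatter), so the bare phenyl group also leaves the number within the scatter of the groups seen before. Nothing given here explains why these four compounds stay so close together.

From the compounds shown here alone, whether an amine or a carboxylic acid on that aromatic carbon would move the number beyond the scatter remains open. The same holds for a longer chain on the aromatic nitrogen and for any change to the shared core.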